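An Added Isopropylcarbonyl on Compound 1

A few compounds are considered here, and "the series" means these few. Any claim that something is new, unique, unknown or untested is made for them only; others in the source may bear on it.

In a physicochemical assay for lipophilicity (a higher number here means a more lipophilic compound, a lower number a more polar compound), compound 1 (`CC(C)C(=O)O[C@H]1[C@H](O)[C@H](n2cnc3c(N)ncnc32)O[C@@H]1CO`) gives 1.06 and stands highest of the two measured compounds. Compound 2 (`CC(=O)O[C@H]1[C@H](O)[C@@H](CO)O[C@H]1n1cnc2c(N)ncnc21`) gives -0.18 on the same scale and lies lower, beyond the scatter. Compound 3 (`CC(C)C(=O)O[C@H]1[C@H](OC(=O)C(C)C)[C@@H](CO)O[C@H]1n1cnc2c(N)ncnc21`) awaits measurement. Relative to compound 1 it carries isopropylcarbonyl in place of hydrogen on an oxygen on a saturated carbon. Among the measured compounds shown here, no measured pair shows this change directly. A rise well beyond the scatter in this assay is expected (a number 1.04 log units higher from compound 1 to compound 3 (beyond the scatter)). Compound 3 is estimated at 2.1 within an expected range (1.6 to 2.7).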

Compound 3, partition coefficient: 1.74
Compound 3: the middle estimate sits 0.36 log units above what was measured; the measured number falls inside the stated range.
By their numbers in this assay, from the lowest: compound 2; then compound 1; then compound 3.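

In this assay, among the compounds shown here, the change of hydroxy to (isopropylcarbonyl)oxy gives a number 0.68 log units higher from compound 1 to compound 3 (beyond the scatter) and is the only step that can be read at this position. It shows that this position responds to the added isopropylcarbonyl in this measure, with a modest step that still lies beyond the scatter. Nothing at hand accounts for the size of the step. The compounds shown leave open how a longer acyl chain, an amine or a carboxylic acid would read on this oxygen, and whether the same change would give a similar step on another oxygen of the shared core.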